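Branching the sulfonyl chain: ethyl to isopropyl

The compounds below may be only part of what the source reports. "The series", "measured", "known", "first", "only" and "open" are said of these compounds alone.

Compound 2 `CCS(=O)(=O)Nc1cccc2c1CCCC2c1c[nH]cn1` stands highest of the three measured compounds in a functional assay on Urethra for agonist activity at Alpha-1A adrenergic receptor (Oryctolagus cuniculus) (a higher number here means a more potent compound, by a factor of ten per unit of this negative logarithm, a lower number a less potent compound), giving 6.77. Compound 1 `O=S(=O)(Nc1cccc2c1CCCC2c1c[nH]cn1)C1CC1` gives 5.25 in this assay, and compound 3 `CS(=O)(=O)Nc1cccc2c1OCCC2c1c[nH]cn1` gives 6. Compound 4 `CC(C)S(=O)(=O)Nc1cccc2c1CCCC2c1c[nH]cn1` differs from compound 2 by methyl in place of hydrogen on a saturated chain carbon bound to a saturated chain carbon and a sulfonyl sulfur. Going by the values given here, only one measured step bears directly on the sulfonyl substituent: the change a number 1.52 log units higher from compound 1 to compound 2 (beyond the scatter), which shows that a three-carbon ring on the sulfonyl sulfur is far weaker than a plain ethyl. Compound 3, carrying a methyl there together with a second change in its core, sits below compound 2 as well. Since isopropyl introduces branching at the carbon bound to the sulfonyl sulfur, a moderate loss is expected, with a step of a number 0.67 log units lower from compound 2 to compound 4 (beyond the scatter). Compound 4 is therefore estimated at 6.1, within 5.2 to 6.9.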

Compound 4, negative logarithm of the half-maximal effective concentration: 5.17
Beside the measured number, compound 4's estimate is 0.93 log units above it; the measured number lies below the stated range.
By their numbers in this assay, from the lowest: compounds 4 and 1 (each within the scatter of the next); then compound 3; then compound 2.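

In this assay, the single methyl that turns ethyl into isopropyl on the sulfonyl sulfur costs a large step (a number 1.60 log units lower from compound 2 to compound 4 (beyond the scatter)), so this position does not tolerate branching at that carbon on the shared core. Isopropyl and cyclopropyl do not separate here (a number 0.08 log units lower from compound 1 to compound 4 (within the scatter)), which leaves ethyl alone at the high value among these three sulfonyl groups. Nothing available explains the loss. Still open, from the compounds shown here alone, is how an unbranched propyl chain or a plain methyl on the sulfonyl sulfur would read on this same core, since compound 3 also differs in its core.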